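This account rests on a few compounds, and the source may have more. Where it says the series, first, only, none or still open, it means among the compounds named here.

Working notes on the series, read in an ADME assay on L6 cells (Rattus norvegicus) for cytotoxicity, read by resazurin assay, with a stated time of 70 h; a lower number here means a stronger inhibitor, a higher number a weaker inhibitor. Among the measured compounds shown here, compound 1 `COc1cc(NC(C)CCCNC(=O)NNC(=O)/C(C)=C/c2ccccc2)c2ncccc2c1` is the only member with a number so far: in this assay compound 1 gives 36500 nM. Compound 2 `COc1cc(NC(C)CCCNC(=O)NNC(=O)NC2CCCC2)c2ncccc2c1` has no usable result, its entry for compound 2 reading "not determined" (no result reported). Compound 3 `COc1cc(NC(C)CCCNC(=O)NNC(=O)NCc2ccccc2)c2ncccc2c1` is in the same position: compound 3 is recorded as "not determined" (no result reported), so it has no place on the scale and gives no number from which to start the next step.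

Compound 4 `COc1cc(NC(C)CCCNC(=O)NNC(=O)Nc2cccc(C(F)(F)F)c2)c2ncccc2c1` differs from compound 3 by a single change: 3-(trifluoromethyl)phenyl in place of benzyl on an amide-type nitrogen. The urea-type chain and the shared core stay as they are, with 3-(trifluoromethyl)phenyl in place of benzyl on an amide-type nitrogen.

For the measured compounds named here, no pair of measured compounds shows what this change does, so the size of the step cannot be read from the data. Going by the values given here, the only reference is compound 1 at 36500 nM. Relative to that level, a modest move toward a lower number in this assay is expected, possibly no larger than the usual scatter. For compound 4 the estimated value is 20000 nM, with an expected range of 6000 nM to 65000 nM.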

Compound 4, half-maximal inhibitory concentration: 32100 nM
Compound 4: the middle estimate sits 1.6-fold (0.21 log units) below what was measured; the range from low to high includes it.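

In this assay compound 4 supplies a second number for the series, and the step reads a 1.1-fold lower number from compound 1 to compound 4 (0.06 log units; within the scatter), with (3-(trifluoromethyl)phenyl)amino in place of 1-methyl-2-phenylethenyl on a carbonyl carbon; compound 1 alone could not show that these two groups, one of them carrying a further amide-type nitrogen, give readings that cannot be told apart at this place. The change from benzyl to 3-(trifluoromethyl)phenyl on the amide-type nitrogen cannot be read, and neither can any other step that starts from or ends at compound 2 or compound 3, as neither compound has a number. No supporting measurement on either compound bears on this result.

With only two numbers in hand, the compounds shown do not tell how far the reading can move at this place, or whether any group on this carbonyl carbon gives a value beyond the scatter from this level. Going by these compounds, it also remains open whether a carboxylic acid or a basic amine on the phenyl ring of compound 4, or a longer chain in place of the one linking the urea-type unit to the shared core, would shift the number.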